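The compounds below may be only part of what the source reports. "The series", "measured", "known", "first", "only" and "open" are said of these compounds alone.

Measured compounds:
compound 1 `CCn1c(=O)[nH]c2ccc(OCCCOc3ccccc3)cc21`, 11.3%
compound 2 `Cn1c(=O)[nH]c2ccc(OCCCc3ccccc3)cc21`, 14%

Of the compounds shown here, two sharing one core have been measured in an assay on cells for inhibition of Amine oxidase [flavin-containing] B (Homo sapiens), read by fluorescence, with stated times of 30 min and 15 min, tested at 1 uM; a lower number here means less inhibition, a higher number more inhibition at the concentration tested (going by the name of the read-out). Compound 1 `CCn1c(=O)[nH]c2ccc(OCCCOc3ccccc3)cc21` gives 11.3%. Compound 2 `Cn1c(=O)[nH]c2ccc(OCCCc3ccccc3)cc21` gives 14%. The two numbers lie within the scatter of each other, so compound 2 stands level with compound 1, and both sit at the low end of the read-out at the concentration tested. Among the measured compounds shown here, no step between these two has been worked out, since they differ in more than one place.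

Compound 3 `CCn1c(=O)[nH]c2ccc(OCCCc3ccccc3)cc21` has not yet been measured in this assay. It differs from compound 2 in one place: methyl in place of hydrogen on a saturated chain carbon bound to an aromatic nitrogen. The same change, cut one bond further out, reads methyl to ethyl.

Since compound 1, which also carries the ethyl, gives 11.3%, the account expects no step beyond the scatter in either direction, with the expected step of a number 1 percentage points lower from compound 2 to compound 3 (within the scatter). Compound 3 is therefore estimated at 13%, with a range from 3% to 25%.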

Compound 3, a percentage reported as inhibition, at one concentration (the size of the read-out at that concentration, not a potency): 4.56%
Compound 3: the middle estimate sits 8.4 percentage points above what was measured, and the stated range covers the measured number.
By their numbers in this assay, from the lowest: compounds 3, 1 and 2 (each within the scatter of the next).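

In this assay the ethyl against the methyl can now be read alone: with a number 9.4 percentage points lower from compound 2 to compound 3 (within the scatter) for methyl in place of hydrogen on a saturated chain carbon bound to an aromatic nitrogen, this change does not move the inhibition beyond the usual scatter. The phenoxy can also be read alone, and with a number 6.7 percentage points lower from compound 1 to compound 3 (within the scatter) for phenyl in place of phenoxy on a saturated chain carbon, three bonds along the chain from an oxygen on an aromatic ring, this second change likewise stays inside the scatter. Both steps hold at the one concentration tested, where all three compounds sit at the low end of the read-out, so they show that neither change lifts the inhibition clear of that range and say nothing about potency.

As far as these compounds go, whether a longer chain such as propyl at this place, or an amine in place of the phenyl at the end of the chain, would bring the read-out out of this low range stays open. Nothing shown here offers a reason for either step.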